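This account rests on a few compounds, and the source may have more. Where it says the series, first, only, none or still open, it means among the compounds named here.

The measured compounds:

compound 1, `C=CCOc1ccc(-c2cn3c(=O)n(-c4ccccc4)nc3c(N)n2)cc1` — "not determined" (no result reported)
compound 2, `O=c1[nH]c(-c2ccc(O)cc2)cn2c(=O)n(-c3ccccc3)nc12` — 207 nM

The study includes compound 1 `C=CCOc1ccc(-c2cn3c(=O)n(-c4ccccc4)nc3c(N)n2)cc1`, for which an assay on cells for displacement of a labelled ligand from adenosine receptor A3 (Homo sapiens), read by scintillation counting, with a stated time of 3 h (a lower number here means a stronger inhibitor, a higher number a weaker inhibitor), reports "not determined" (no result reported). Among the measured compounds shown here, the only value therefore belongs to compound 2 `O=c1[nH]c(-c2ccc(O)cc2)cn2c(=O)n(-c3ccccc3)nc12`, which in this assay gives 207 nM. Compound 2 thus stands alone on the numbers shown; nothing can be said about its rank, since there is no second value to set beside it.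

Compound 3 `COc1ccc(-c2cn3c(=O)n(-c4ccccc4)nc3c(=O)[nH]2)cc1` remains to be measured. It differs from compound 2 in a single place: methyl in place of hydrogen on an oxygen on an aromatic ring. The change is small in size and introduces no ring and no new donor or acceptor.

For the measured compounds named here, no step between two measured compounds is available, so the effect of this change cannot be read from the data themselves. The author expects a step from compound 2 to compound 3 of a 1.4-fold higher number from compound 2 to compound 3 (0.16 log units; within the scatter), a modest shift that would not clearly stand out from the usual scatter. On that basis compound 3 is estimated at 300 nM in this assay, within a range of 90 nM to 1000 nM.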

Compound 3, inhibition constant: > 30000 nM
Compound 3: no number, only a limit; the forecaster's own chance of this, stated with the estimate: 10%; middle value at least 100-fold (2.00 log units) away from the limit.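

In this assay compound 3 gives > 30000 nM, which is a limit of the assay and not a number. The earlier compounds offered no step at all, and this one shows that the oxygen on the aromatic ring is a sensitive place in this series: going from hydroxy to methoxy, which adds only a single methyl and no ring, gives an at least 140-fold higher number from compound 2 to compound 3 (2.16 log units; beyond the scatter), so a free hydroxy at this position goes with the only measured affinity shown. The step gives only a lower bound on the true size of the change, because the reading for compound 3 is not an exact value: the limit of > 30000 nM in this assay, at which 1 of the 3 values shown sits.

The compounds shown leave open whether any replacement of this hydrogen has the same outcome or only methyl does, and whether another group in place of the hydroxy, such as an amine, a fluorine or a carboxylic acid, would keep a measurable value in this assay. Compound 1 has no result in this assay, so it gives no further reading on this position, and the whole picture rests on a single pair.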